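This account rests on a few compounds, and the source may have more. Where it says the series, first, only, none or still open, it means among the compounds named here.

Measured so far in a functional assay on A549 cells (Homo sapiens) for antiproliferative activity, read by MTT assay, with a stated time of 72 h; a lower number here means a stronger inhibitor, a higher number a weaker inhibitor (lower numbers mean a stronger inhibitor):

- compound 1 `CCCCCCCCCCNC[C@@H]1OC[C@H](N)[C@@H]1O` gives 47800 nM
- compound 2 `CCCCCCCCCCCNC[C@@H]1OC[C@H](N)[C@@H]1O` gives 11100 nM
- compound 3 `CCCCCCCCCCCCCCNC[C@@H]1OC[C@H](N)[C@H]1O` gives 20000 nM

Compound 3 sits within the scatter of compound 2 and lower than compound 1 by more than the scatter. Compound 4 `CCCCCCCCCCCCCCNC[C@@H]1OC[C@H](N)[C@@H]1O` differs from it only in configuration as drawn (the two compounds have the same atoms and bonds and differ only in configuration as drawn: 1 of 3 stereo elements differ; a stereocentre at a saturated ring carbon is drawn R in compound 3 and S in compound 4): a stereocentre at a saturated ring carbon is drawn R in compound 3 and S in compound 4. Within the data shown here, the only measured step (a 4.3-fold lower number from compound 1 to compound 2 (0.63 log units; beyond the scatter)) is a modest chain change, so no measured step tests configuration. No step beyond the scatter is therefore expected in this assay, though the range stays wide. The expected step is small (a 1.4-fold lower number from compound 3 to compound 4 (0.15 log units; within the scatter)). For compound 4 the estimated value is 14000 nM (expected range 6000 nM to 32000 nM).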

Compound 4, half-maximal inhibitory concentration: 2850 nM
Estimate against measurement, compound 4: 4.9-fold (0.69 log units) above; measured number outside the range, below it.
By their numbers in this assay, from the lowest: compound 4; then compounds 2 and 3 (each within the scatter of the next); then compound 1.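

In this assay, the stereocentre at this saturated ring carbon clearly matters: changing it from R to S gives a 7.0-fold lower number from compound 3 to compound 4 (0.85 log units; beyond the scatter). Only that centre can account for this step, because nothing else separates the pair: the fact that compounds 3 and 4 differ only in the configuration as drawn. With the S drawing kept, propyl in place of hydrogen on the chain gives a 3.9-fold lower number from compound 2 to compound 4 (0.59 log units; beyond the scatter), and butyl in its place gives a 17-fold lower number from compound 1 to compound 4 (1.22 log units; beyond the scatter).

Going by these compounds, whether a longer chain would lower the number further remains open. So does whether the R drawing would cost as much on the chains of compound 1 and compound 2.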